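Cytotoxicity notes: methoxy for chloro on the aryl ring

The source may hold more compounds than are shown below. What is called first, only, known or untested is meant among the compounds shown, and "the series" means these compounds.

Compound 1 `Fc1ccc(C2CC(c3ccc(Cl)s3)=NN2c2nc(-c3ccc(Br)cc3)cs2)cc1` in an ADME assay on NIH3T3 cells (Mus musculus) for cytotoxicity, read by XTT assay, with a stated time of 24 h (on this read-out lower numbers stand for stronger inhibition and higher numbers for weaker inhibition), gives > 500 ug/mL, which is a limit of the assay.
Compound 2 `Cc1ccc(C2=NN(c3nc(-c4ccc(Cl)cc4)cs3)C(c3ccc(F)cc3)C2)s1` in this assay gives > 500 ug/mL, a limit of the assay.
Compound 3 `Cc1ccc(C2=NN(c3nc(-c4ccc(F)cc4)cs3)C(c3ccc(F)cc3)C2)s1` in this assay gives > 500 ug/mL, again a limit of the assay.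

Compound 2 stands on the numbers only as a limit, and the two further values shown are limits as well. Among the measured compounds shown here, the one measured step that touches this position is the step that the two limits leave unreadable from compound 2 to compound 3, fluoro in place of chloro on an aromatic carbon; its size cannot be read because of the limit of > 500 ug/mL in this assay, at which 3 of the 3 values shown sit.

The unmeasured compound 4 `COc1ccc(-c2csc(N3N=C(c4ccc(C)s4)CC3c3ccc(F)cc3)n2)cc1` differs from compound 2 by methoxy in place of chloro on an aromatic carbon. The measured step bears on the same position but gives no readable size, so for compound 4 no step beyond the scatter in this assay can be expected in either direction, and the outcome is most likely another limit. The expected step that the limit leaves unreadable from compound 2 to compound 4 is therefore estimated as flat. For compound 4 the estimate in this assay is 700 ug/mL, with a range from 350 ug/mL to 1500 ug/mL.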

Compound 4, half-maximal inhibitory concentration: 147 ug/mL
Compound 4: middle estimate off by 4.8-fold (0.68 log units), on the high side; measured number outside the range, below it.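

In this assay, methoxy in place of chloro gives an at least 3.4-fold lower number from compound 2 to compound 4 (0.53 log units; beyond the scatter), and methoxy in place of fluoro gives an at least 3.4-fold lower number from compound 3 to compound 4 (0.53 log units; beyond the scatter). The position on the six-membered aromatic ring is therefore not silent: a single change there is enough to bring a value off the limit, and 4-methoxyphenyl is the only aryl group shown in this one-place series that does so. Both steps give only a minimum size, and the step between the two halogen compounds still cannot be read: the limit of > 500 ug/mL in this assay, at which 3 of the 4 values shown sit.

As far as these compounds go, how far compound 2 and compound 3 really lie from compound 4 remains open, so the full size of both steps is unknown. Also open, from the compounds shown here alone, is whether the shift is specific to methoxy or would also appear with an amine, a hydroxyl or a longer chain such as ethoxy at the same place.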